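Removing the Pyridinyl Group from a Sulfonamide Inhibitor

This account rests on a few compounds, and the source may have more. Where it says the series, first, only, none or still open, it means among the compounds named here.

Measured compounds:
- Compound 1, `NC(=S)NNc1nncc2ccccc12`, gives 74 nM in a functional assay on OVCAR-3 cells (Homo sapiens) for antiproliferative activity, read by sulforhodamine B assay, with a stated time of 72 h; on this read-out higher numbers stand for weaker inhibition and lower numbers for stronger inhibition.
- Compound 2, `O=S(=O)(Nc1ccccn1)c1ccc(Nc2nncc3ccccc23)cc1`, gives 83 nM.
- Compound 3, `COc1ccc(NC(=S)NNc2nncc3ccccc23)cc1`, gives 73 nM.

All three compounds share a core and were tested in this assay, where they return numbers that lie within the usual scatter of one another, so compound 2 cannot be placed apart from compound 1 or compound 3 on these data. Compound 4, `NS(=O)(=O)c1ccc(Nc2nncc3ccccc23)cc1`, has not yet been measured. It differs from compound 2 in one place: hydrogen in place of pyridin-2-yl on a sulfonamide nitrogen. Among the measured compounds shown here, no measured pair shows the effect of this change, so the expectation rests on the closeness of the three numbers so far. A step of modest size, if any, toward a higher number is expected from compound 2 to compound 4, a 1.4-fold higher number from compound 2 to compound 4 (0.16 log units; within the scatter). Compound 4 is estimated at 120 nM, with a range from 40 nM to 400 nM.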

Compound 4, half-maximal inhibitory concentration: 14 nM
Compound 4: the middle estimate sits 8.6-fold (0.93 log units) above what was measured; measured number outside the range, below it.
By their numbers in this assay, from the lowest: compound 4; then compounds 3, 1 and 2 (each within the scatter of the next).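

In this assay the sulfonamide nitrogen proves sensitive to what it carries: hydrogen in place of pyridin-2-yl gives a 5.9-fold lower number from compound 2 to compound 4 (0.77 log units; beyond the scatter) in an otherwise unchanged compound. The pyridin-2-yl group is therefore not needed for this activity, and losing it improves the result, something the three closely spaced earlier numbers could not reveal. Nothing among the data shown explains why this step occurs.

Going by these compounds, what a methyl group or a phenyl ring on this nitrogen would give remains open. So does whether a longer chain there would land nearer compound 4 or compound 2.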